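Thiazolidinone amides: ring-nitrogen aryl swap in compound 4

This account rests on a few compounds, and the source may have more. Where it says the series, first, only, none or still open, it means among the compounds named here.

Measured so far:
compound 1 `CCN(CC)c1ccc(N2C(=O)CSC2c2cccc(C(=O)NCCCCc3ccccc3)c2)cc1` — > 1000 nM
compound 2 `COc1ccc(F)cc1N1C(=O)CSC1c1cccc(C(=O)NCCCCn2cccn2)c1` — 97.3 nM
compound 3 `COc1ccc(F)cc1N1C(=O)CSC1c1cccc(C(=O)NCCCCc2ccccc2)c1` — 8.8 nM

All three share the same core and were tested in a functional assay on HOS-TE85 cells (Homo sapiens) for inhibition, read by CCK-8 assay, with a stated time of 72 h; on this read-out lower numbers stand for stronger inhibition and higher numbers for weaker inhibition. For compound 1 the entry > 1000 nM is a limit of the assay, not a number. Of the two compounds with numbers, compound 2 gives the higher one, 97.3 nM, and compound 3 sits an 11-fold lower number from compound 2 to compound 3 (1.04 log units; beyond the scatter) away through phenyl in place of 1H-pyrazol-1-yl on the saturated chain carbon, four bonds along the chain from the amide-type nitrogen.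

Compound 4 `O=C(NCCCCn1cccn1)c1cccc(C2SCC(=O)N2c2cc(F)ccn2)c1` keeps the chain and 1H-pyrazol-1-yl end of compound 2 and changes only the aryl on the amide-type nitrogen in the ring: 4-fluoropyridin-2-yl in place of 5-fluoro-2-methoxyphenyl on an amide-type nitrogen in a ring.

For the measured compounds named here, the one measured step at that position, an at least 110-fold lower number from compound 1 to compound 3 (2.05 log units; beyond the scatter), shows the ring-nitrogen aryl can shift the read-out by a large margin, with 5-fluoro-2-methoxyphenyl on the favourable side and the limit of > 1000 nM in this assay, at which 1 of the 3 values shown sits, setting the other end. Going by the values given here, no measured step compares 5-fluoro-2-methoxyphenyl with a pyridine at this position, so the direction is uncertain; a sizeable move is possible either way, and a weaker result is taken as somewhat more likely since the replaced group is the one that works.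

Compound 4 is therefore expected to give about 250 nM, within 60 nM to 1500 nM. This estimate corresponds to an expected step of a 2.6-fold higher number from compound 2 to compound 4 (0.41 log units; beyond the scatter).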

Compound 4, half-maximal inhibitory concentration in the HOS-TE85 assay: 33.2 nM
Beside the measured number, compound 4's estimate is 7.5-fold (0.88 log units) above it; measured number outside the range, below it.
By their numbers in the HOS-TE85 assay, from the lowest: compound 3; then compound 4; then compound 2. At a limit, above all of these: compound 1.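

In the HOS-TE85 assay the swap at this position gives a 2.9-fold lower number from compound 2 to compound 4 (0.47 log units; beyond the scatter), with the chain and its 1H-pyrazol-1-yl end held fixed. 5-fluoro-2-methoxyphenyl is therefore not the only favourable aryl on the amide-type nitrogen: in this pair a six-membered aromatic ring with 1 hetero atom and no methoxy does better, which the step between compound 1 and compound 3 could not show, as it involved no ring of this kind. In a physicochemical assay for solubility, read by turbidimetry, measured as kinetic solubility, at pH 7.4 (on this read-out higher numbers stand for higher solubility and lower numbers for lower solubility), compound 2 gives 50000 nM and compound 4 gives 50000 nM. In the physicochemical assay the same pair does not separate, with no change at the digits printed from compound 2 to compound 4 (within the scatter).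

Compound 1 stands at a limit of the assay, not a number, so the weak end of the range at this position has no size yet: the limit of > 1000 nM in the HOS-TE85 assay, at which 1 of the 4 values shown sits.

From the compounds shown here alone, it remains open in the HOS-TE85 assay whether 4-fluoropyridin-2-yl carries over to the phenyl chain end of compound 3, which gives 8.8 nM, and whether the fluorine on the pyridine matters, which an unsubstituted pyridin-2-yl or a chloropyridine at the same place would test.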